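Moving the Pyridine Nitrogen on a Weak Compound

The source may report more compounds than this note shows. Statements on the series, on what has been measured and on what is new or still open speak of the compounds shown alone.

In a functional assay on MES-SA/Dx5 cells (Homo sapiens) for inhibition, with a stated time of 72 h (on this read-out higher numbers stand for weaker inhibition and lower numbers for stronger inhibition), compound 1 `Oc1c(CN2CCCC2)ccc2cccnc12` gives 1470 nM; 1450 nM (2 entries) and compound 2 `CC1CCN(Cc2cc(Cl)c3cccnc3c2O)CC1` gives 260 nM; 257 nM (2 entries). Compound 3 `Oc1c(C(c2cccnc2)N2CCCC2)ccc2cccnc12` gives 23400 nM, a much higher number than either, which means far weaker inhibition. Two further entries for compound 3 carry no single number. Compound 4 `Oc1c(C(c2ccncc2)N2CCCC2)ccc2cccnc12` has the same atoms as compound 3, joined differently: pyridin-4-yl in place of pyridin-3-yl on a saturated chain carbon bound to an amine nitrogen in a ring and an aromatic carbon, with pyridin-4-yl in place of pyridin-3-yl on a saturated chain carbon bound to an amine nitrogen in a ring and an aromatic carbon. Among the compounds with values here, no measured pair here shows such a swap, so only a small change is expected, with no shift beyond the usual scatter: the expected step is a 1.6-fold lower number from compound 3 to compound 4 (0.19 log units; within the scatter). Compound 4 is estimated at 15000 nM, with an expected range from 4500 nM to 45000 nM.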

Compound 4, half-maximal inhibitory concentration: 3630 nM
Estimate against measurement, compound 4: 4.1-fold (0.62 log units) above; the whole stated range lies above it.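

In this assay, the saturated chain carbon bound to the ring amine nitrogen and an aromatic carbon proves sensitive to a small change: pyridin-4-yl in place of pyridin-3-yl gives a 6.4-fold lower number from compound 3 to compound 4 (0.81 log units; beyond the scatter). The two compounds have the same atoms, so how those atoms are joined is enough to shift the number. Nothing measured here explains this shift. Going by these compounds, whether pyridin-2-yl or a plain phenyl ring on this carbon would lower the number further remains open.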